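This account rests on a few compounds, and the source may have more. Where it says the series, first, only, none or still open, it means among the compounds named here.

Measured so far:
- In a functional assay on HT-29 cells (Homo sapiens) for cytotoxicity, read by sulforhodamine B assay, with a stated time of 48 h (on this read-out higher numbers stand for weaker inhibition and lower numbers for stronger inhibition), compound 1 `CCc1ccccc1OS(=O)(=O)c1cccc(NC(=O)NCCCCl)c1` gives 23000 nM.
- In this assay compound 2 `O=C(NCCCCl)Nc1cccc(S(=O)(=O)Oc2ccc(O)cc2)c1` gives 51000 nM.
- In this assay compound 3 `CCNC(=O)Nc1ccc(S(=O)(=O)Oc2ccccc2CC)cc1` gives 12000 nM.

Compound 4 `CCNC(=O)Nc1ccc(S(=O)(=O)Oc2ccc(O)cc2)cc1` has not been measured yet. It is built on the core of compound 3; how that core differs from the core of compound 1 is not broken down here. Among the three measured compounds, compound 3 has the lowest number, but its gap to compound 1 lies within the usual scatter, while its gap to compound 2 lies beyond it.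

One structural change appears twice in this set. Going from compound 1 to compound 2 the change is 4-hydroxyphenyl in place of 2-ethylphenyl on an oxygen, and in this assay it produced a 2.2-fold higher number from compound 1 to compound 2 (0.35 log units; beyond the scatter). The change from compound 3 to compound 4 is 4-hydroxyphenyl in place of 2-ethylphenyl on an oxygen, the same change at the same kind of place. Because compound 1 to compound 2 gave a 2.2-fold higher number from compound 1 to compound 2 (0.35 log units; beyond the scatter), a step of similar size and direction is expected for compound 4, namely a 2.2-fold higher number from compound 3 to compound 4 (0.34 log units; beyond the scatter). Compound 4 is therefore estimated at 26000 nM, with a likely range from 12000 nM to 55000 nM.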

Compound 4, half-maximal inhibitory concentration: 12000 nM
Compound 4: middle estimate off by 2.2-fold (0.34 log units), on the high side; the range from low to high includes it.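

In this assay, putting 4-hydroxyphenyl in place of 2-ethylphenyl on the oxygen bonded to the sulfonyl sulfur gives no change at the digits printed from compound 3 to compound 4 (within the scatter). At first sight this looks different from the earlier step, but the gap between the two steps is no larger than two such steps would be expected to show from ordinary scatter alone, so these data give no sign that the core alters the effect of this change: the same change on two cores in this assay, a 2.2-fold higher number (0.35 log units; beyond the scatter) from compound 1 to compound 2 and no change at the digits printed (within the scatter) from compound 3 to compound 4, 2.2-fold (0.35 log units) apart, within the scatter of two such steps. Going by these compounds alone, this does not prove that the change carries over unaltered, as there are only two pairs, one step lies beyond the scatter and the other within it, and the true size of the step on either core stays uncertain.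

The compounds shown leave open how this series would respond to an amine or a carboxylic acid in place of the hydroxy group, or to a longer chain in place of the ethyl group on the phenyl ring. They also leave open whether the same swap would behave alike on a third core.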